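Swapping the Sulfonyl Aryl Group for a Nitrophenyl

This account rests on a few compounds, and the source may have more. Where it says the series, first, only, none or still open, it means among the compounds named here.

In a functional assay on HCT-116 cells (Homo sapiens) for antiproliferative activity, read by MTT assay, with a stated time of 72 h (a higher number here means a weaker inhibitor, a lower number a stronger inhibitor), compound 2 `COc1ccc(S(=O)(=O)N(C)c2ccc3[nH]c(-c4n[nH]c5ccccc45)cc3n2)c(OC)c1` gives 21800 nM. Compound 1 `COc1ccc(S(=O)(=O)N(C)c2ccc3[nH]c(-c4n[nH]c5ccccc45)cc3n2)cc1` gives 22400 nM in this assay. The step of a 1.0-fold lower number from compound 1 to compound 2 (0.01 log units; within the scatter) leaves the two within the scatter of each other. Compound 3 `CN(c1ccc2[nH]c(-c3n[nH]c4ccccc34)cc2n1)S(=O)(=O)c1cccc([N+](=O)[O-])c1` carries 3-nitrophenyl in place of 2,4-dimethoxyphenyl on a sulfonyl sulfur. Within the data shown here, no measured step exchanges the whole aryl group on the sulfonyl sulfur; the single step that altered this ring produced nothing beyond the scatter, so for compound 3 a step no larger than the scatter is expected, a 1.1-fold lower number from compound 2 to compound 3 (0.04 log units; within the scatter). Compound 3 is estimated at 20000 nM, with a range from 7000 nM to 60000 nM.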

Compound 3, half-maximal inhibitory concentration: 13600 nM
Beside the measured number, compound 3's estimate is 1.5-fold (0.17 log units) above it; measured number inside the range.
By their numbers in this assay, from the lowest: compounds 3, 2 and 1 (each within the scatter of the next).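

Exchanging the whole aryl group on the sulfonyl sulfur, a larger change than adding one methoxy, gives in this assay a 1.6-fold lower number from compound 2 to compound 3 (0.20 log units; within the scatter) and a 1.6-fold lower number from compound 1 to compound 3 (0.22 log units; within the scatter). At this position, 3-nitrophenyl, 2,4-dimethoxyphenyl and 4-methoxyphenyl are therefore not separated by this read-out. No evidence accompanies this result that could explain it.

From the compounds shown here alone, whether an amine or a carboxylic acid on this aryl ring would give a step beyond the scatter stays open. So does the effect of a saturated alkyl chain in place of the aryl group.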